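This account rests on a few compounds, and the source may have more. Where it says the series, first, only, none or still open, it means among the compounds named here.

Compound 1 `CCOc1nc(C(C)(C)C)ccc1CNC(=O)C(C)c1ccc(NS(C)(=O)=O)c(F)c1` is the starting point of this account. Among the compounds with values here, in an assay on cells for antagonist activity at transient receptor potential cation channel subfamily V member 1 (Homo sapiens), read by FLIPR and calcium flux, with a stated time of 6 min (on this read-out higher numbers stand for weaker inhibition and lower numbers for stronger inhibition), compound 1 gives 14.8 nM, the lowest of the two numbers measured so far. Within the data shown here, its nearest neighbour is compound 2 `CC(C(=O)NCc1ccc(C(C)(C)C)nc1SCCCN(C)C)c1ccc(NS(C)(=O)=O)c(F)c1`, which in this assay gives 51.8 nM; the single change between them, (3-(dimethylamino)propyl)sulfanyl in place of ethoxy on an aromatic carbon, produces a 3.5-fold higher number from compound 1 to compound 2 (0.54 log units; beyond the scatter).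

The compound now in question is compound 3 `CC(C(=O)NCc1ccc(C(C)(C)C)nc1SC1CCCC1)c1ccc(NS(C)(=O)=O)c(F)c1`. Compared with compound 1 it carries cyclopentylsulfanyl in place of ethoxy on an aromatic carbon. Among the measured compounds shown here, the one measured step that bears on this change is the exchange of the same ethoxy for a sulfanyl-linked group, which gave a 3.5-fold higher number from compound 1 to compound 2 (0.54 log units; beyond the scatter). That group carried a basic chain, whereas cyclopentylsulfanyl brings a five-membered non-aromatic ring of carbon only, so the earlier step is only a partial guide. For the measured compounds named here, on that basis a modest weakening is expected, smaller than the one seen for compound 2 but not certain to clear the scatter. Compound 3 is therefore estimated in this assay at 30 nM, with a range from 8 nM to 110 nM. This estimate corresponds to an expected step of a 2.0-fold higher number from compound 1 to compound 3 (0.31 log units; beyond the scatter).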

Compound 3, inhibition constant: 2.5 nM
Compound 3: the middle estimate sits 12-fold (1.08 log units) above what was measured; measured number below the stated range.
By their numbers in this assay, from the lowest: compound 3; then compound 1; then compound 2.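

In this assay the exchange of ethoxy for cyclopentylsulfanyl, on the aromatic carbon next to the ring nitrogen, gives a 5.9-fold lower number from compound 1 to compound 3 (0.77 log units; beyond the scatter) and leaves compound 3 as the strongest inhibitor of the three. A sulfur at this position therefore does not in itself go with a higher number: the two exchanges of ethoxy for a sulfanyl-linked group run in opposite directions, and what decides the direction here is the group carried on the sulfur. That group alone accounts for a 21-fold lower number from compound 2 to compound 3 (1.32 log units; beyond the scatter), a larger step than either exchange made from compound 1, and the data give no explanation for it.

The compounds shown leave open how much of the gain belongs to the sulfur and how much to the cyclopentyl ring, as the two enter together; cyclopentyloxy and ethylsulfanyl at this position would pull them apart. They also leave open whether the step between compound 2 and compound 3 follows from the loss of the dimethylamino group or from the ring, which a plain propyl or a cyclohexyl on the sulfur would help to decide.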